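Pyrimidine series: extending the side chain with a pyrrolidine

The source may report more compounds than this note shows. Statements on the series, on what has been measured and on what is new or still open speak of the compounds shown alone.

Measured so far:
compound 1 `CCCCNc1nc(N)nc(C)c1CC`, 1660 nM
compound 2 `CCCCCc1c(C)nc(N)nc1NCCCC`, 1220 nM

Going by the values given here, in an assay on HEK293 cells for agonist activity at Toll-like receptor 8 (Homo sapiens), read by spectrophotometry (on this read-out higher numbers stand for an effect only at larger amounts of compound and lower numbers for an effect already at smaller amounts), compound 2 stands next to compound 1, the two numbers lying within the scatter of one another; the only measured step, a 1.4-fold lower number from compound 1 to compound 2 (0.13 log units; within the scatter), is a chain extension and not a change of this kind.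

Compound 3 `CCCCNc1nc(N)nc(C)c1CCCN1CCCC1` is not yet measured. Relative to compound 2 it carries pyrrolidin-1-yl in place of ethyl on a saturated chain carbon, three bonds along the chain from an aromatic carbon. Among the compounds with values here, no measured pair introduces a ring or an acceptor at this chain position, so the one known step offers little guidance beyond showing that a change on the chain near this place left the number about where it was.

Compound 3 is therefore expected to land near compound 2, with the step of a 1.4-fold lower number from compound 2 to compound 3 (0.13 log units; within the scatter) estimated as small and of uncertain direction, the value estimated at 900 nM within a wide range of 150 nM to 5000 nM.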

Compound 3, half-maximal effective concentration: 110 nM
Compound 3: middle estimate off by 8.2-fold (0.91 log units), on the high side; measured number below the stated range.
By their numbers in this assay, from the lowest: compound 3; then compounds 2 and 1 (each within the scatter of the next).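

Placing pyrrolidin-1-yl in place of ethyl on this saturated chain carbon, three bonds along the chain from an aromatic carbon, gives in this assay an 11-fold lower number from compound 2 to compound 3 (1.04 log units; beyond the scatter) as its result, so this position does respond to the group it carries, which a 1.4-fold lower number from compound 1 to compound 2 (0.13 log units; within the scatter) alone had not shown. Read against the shorter chain, (pyrrolidin-1-yl)methyl in place of hydrogen gives a 15-fold lower number from compound 1 to compound 3 (1.18 log units; beyond the scatter) on the same read-out, so the added propyl and the added ring-bearing group part ways at this place. Nothing available accounts for the size of this step.

Still open, as far as these compounds go, is whether the ring or its nitrogen carries the step: a cyclopentyl group or a diethylamino group at the same place would separate the two. Also open, from the compounds shown here alone, are piperidin-1-yl as the ring and a longer chain leading to pyrrolidin-1-yl.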